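Replacing the Fluorinated Ring of Compound 2 with a Dichlorinated One

The source may hold more compounds than are shown below. What is called first, only, known or untested is meant among the compounds shown, and "the series" means these compounds.

Measured in a functional assay on PC-3 cells (Homo sapiens) for antiproliferative activity, read by MTT assay, tested at 1 uM; on this read-out lower numbers stand for a weaker effect and higher numbers for a stronger effect at the one concentration tested:
Compound 1 `COc1ccc(OC)c(/C=N/NC(=O)c2cc(OC)c(OC)c(OC)c2)c1`: 30.9%
Compound 2 `COc1cc(C(=O)N/N=C/c2ccccc2F)cc(OC)c1OC`: 70.6%
Compound 3 `COc1cc(C(=O)N/N=C/c2ccc(C(F)(F)F)cc2)cc(OC)c1OC`: 59.9%

Compound 2 stands highest of the three numbers. Its nearest neighbour is compound 3, lower by a gap beyond the scatter, and its furthest is compound 1, lower still.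

Compound 4 `COc1cc(C(=O)N/N=C/c2cc(Cl)cc(Cl)c2)cc(OC)c1OC` has not yet been measured. It differs from compound 2 in one place: 3,5-dichlorophenyl in place of 2-fluorophenyl on a carbon with a double bond to nitrogen.

Going by the values given here, no step between two measured compounds carries this change, so the size can only be guessed. In this assay a modest fall is expected for compound 4 relative to compound 2, of about the usual scatter or slightly more, with a number 15.6 percentage points lower from compound 2 to compound 4 (beyond the scatter). Compound 4 is therefore expected to give 55%, within 35% to 75%.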

Compound 4, a percentage reported as inhibition, at one concentration (the size of the read-out at that concentration, not a potency): 22.1%
For compound 4 the middle estimate is 32.9 percentage points above the measured one; the measured number lies below the stated range.
By their numbers in this assay, from the lowest: compounds 4 and 1 (each within the scatter of the next); then compound 3; then compound 2.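

Swapping 2-fluorophenyl for 3,5-dichlorophenyl on the shared core gives a number 48.5 percentage points lower from compound 2 to compound 4 (beyond the scatter) in this assay. This position is therefore sensitive to which ring it carries, and a halogen on that ring does not by itself keep the effect. Nothing available explains this loss.

Going by these compounds, whether the loss follows from the chlorine atoms themselves or from where they sit on the ring stays open. So does the effect of a ring carrying an amine or a carboxylic acid on this carbon.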